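This account rests on a few compounds, and the source may have more. Where it says the series, first, only, none or still open, it means among the compounds named here.

Measured compounds in an in vitro ADME assay on microsomes from liver (Canis lupus familiaris) for metabolic stability, tested at 5 uM; on this read-out higher numbers stand for a longer-lived compound and lower numbers for a shorter-lived compound:
- Compound 1 `C=CC(=O)NCc1coc(-c2c(N)ncnc2Nc2ccc(Oc3ccccc3)c(Cl)c2)n1` gives > 1.66 h, which is a limit of this assay, not a number.
- Compound 2 `C=CC(=O)NCc1coc(-c2c(N)ncnc2Nc2ccc(Oc3cc(Cl)ccc3Cl)c(Cl)c2)n1` gives > 1.66 h, which is again a limit of this assay.
- Compound 3 `C=CC(=O)NCc1coc(-c2c(N)ncnc2Nc2ccc(Oc3ccccn3)c(Cl)c2)n1` gives 0.4 h.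

Among the measured compounds shown here, compound 3 therefore stands as the only compound here with a numerical half-life; the other two sit at the limit (the limit of > 1.66 h in this assay, at which 2 of the 3 values shown sit). Relative to both of them it reads lower: an at least 4.1-fold lower number from compound 1 to compound 3 (0.61 log units; beyond the scatter) and an at least 4.1-fold lower number from compound 2 to compound 3 (0.61 log units; beyond the scatter). The step from compound 1 to compound 2, a step that the two limits leave unreadable from compound 1 to compound 2, tells nothing about the size of that change.

Compound 4 `C=CC(=O)NCc1coc(-c2c(N)ncnc2Nc2ccc(Oc3cccnc3)c(Cl)c2)n1` differs from compound 3 by pyridin-3-yl in place of pyridin-2-yl on an oxygen on an aromatic ring. For the measured compounds named here, no measured step compares the two pyridyl rings directly; the steps known concern the swap of a phenyl or a 2,5-dichlorophenyl for a pyridin-2-yl, and both of those lowered the half-life at least modestly. Compound 4 keeps a pyridyl ring, so a number close to that of compound 3 is expected, with a step of a 1.5-fold higher number from compound 3 to compound 4 (0.18 log units; within the scatter) that is estimated to lie within the scatter. The estimate for compound 4 in this assay is 0.6 h, between 0.25 h and 1.6 h.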

Compound 4, half-life: 0.65 h
Estimate against measurement, compound 4: 1.1-fold (0.03 log units) below; the measured number falls inside the stated range.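

In this assay, pyridin-3-yl in place of pyridin-2-yl on the oxygen gives a 1.6-fold higher number from compound 3 to compound 4 (0.21 log units; within the scatter), so this read-out does not separate the two pyridyl rings. The loss seen earlier with pyridin-2-yl therefore also holds for pyridin-3-yl, which gives an at least 2.5-fold lower number from compound 1 to compound 4 (0.40 log units; beyond the scatter) and an at least 2.5-fold lower number from compound 2 to compound 4 (0.40 log units; beyond the scatter). These two steps give only a minimum size because compound 1 and compound 2 each sit at a limit, not a number: the limit of > 1.66 h in this assay, at which 2 of the 4 values shown sit.

On these data alone, how far the half-lives of compound 1 and compound 2 extend past that limit remains open, and so does the true size of the gap to either pyridyl ring. Also open, as far as these compounds go, is how a pyrimidine ring or a methoxyphenyl ring on the same oxygen would read.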